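The source may hold more compounds than are shown below. What is called first, only, known or untested is meant among the compounds shown, and "the series" means these compounds.

Measured compounds and their values:

- Compound 1, `Cc1ccc(CN2CCN(C(=O)CN[C@H]3CCN(S(=O)(=O)Cc4ccccc4)C3)CC2)cc1`, gives 8200 nM in a functional assay on K562 cells (Homo sapiens) for cytotoxicity, read by MTT assay, with a stated time of 48 h; a higher number here means a weaker inhibitor, a lower number a stronger inhibitor.
- Compound 2, `O=C(CN[C@H]1CCN(S(=O)(=O)Cc2ccccc2)C1)N1CCN(Cc2ccccc2Cl)CC1`, gives 9000 nM in this assay.
- Compound 3, `COc1cccc(CN2CCN(C(=O)CN[C@H]3CCN(S(=O)(=O)Cc4ccccc4)C3)CC2)c1`, gives 60800 nM in this assay.

Compound 2 stands second highest of the three numbers. Its nearest neighbour is compound 1, with a step of a 1.1-fold higher number from compound 1 to compound 2 (0.04 log units; within the scatter); its furthest is compound 3, with a 6.8-fold higher number from compound 2 to compound 3 (0.83 log units; beyond the scatter). Compound 4, `COc1ccc(CN2CCN(C(=O)CN[C@H]3CCN(S(=O)(=O)Cc4ccccc4)C3)CC2)cc1`, is not yet measured in this assay. It differs from compound 2 in one place: 4-methoxyphenyl in place of 2-chlorophenyl on a saturated chain carbon bound to an amine nitrogen in a ring.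

For the measured compounds named here, two measured steps bear on this change. The step of a 6.8-fold higher number from compound 2 to compound 3 (0.83 log units; beyond the scatter) shows that a methoxyphenyl of a different kind weakened the compound, and a 7.4-fold higher number from compound 1 to compound 3 (0.87 log units; beyond the scatter) shows the same from the 4-methylphenyl analogue. The step of a 1.1-fold higher number from compound 1 to compound 2 (0.04 log units; within the scatter) shows that exchanging 4-methylphenyl for 2-chlorophenyl left the number where it was. Going by the values given here, no measured step covers 4-methoxyphenyl itself, so the direction is uncertain; a modest weakening is expected, as a 2.0-fold higher number from compound 2 to compound 4 (0.30 log units; within the scatter). Compound 4 is therefore estimated at 18000 nM, within 6000 nM to 55000 nM.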

Compound 4, half-maximal inhibitory concentration: 50900 nM
The estimate for compound 4 lay 2.8-fold (0.45 log units) below the measured number; the range from low to high includes it.
By their numbers in this assay, from the lowest: compounds 1 and 2 (each within the scatter of the next); then compounds 4 and 3 (each within the scatter of the next).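

In this assay, for the compounds shown here, 4-methoxyphenyl in place of 2-chlorophenyl gave a 5.7-fold higher number from compound 2 to compound 4 (0.75 log units; beyond the scatter) and methoxy in place of methyl on an aromatic carbon gave a 6.2-fold higher number from compound 1 to compound 4 (0.79 log units; beyond the scatter), so the weakening earlier seen only with 3-methoxyphenyl now appears with a second methoxyphenyl. The step between the two methoxyphenyl compounds, a 1.2-fold lower number from compound 3 to compound 4 (0.08 log units; within the scatter), shows that this assay does not separate them, leaving these two as a weaker pair and compounds 1 and 2 as a stronger pair. Nothing measured here explains this split between the pairs.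

The compounds shown leave open whether the loss belongs to methoxy specifically or would also follow a hydroxyl or an amine on the phenyl ring. They also leave open where an unsubstituted phenyl on the same saturated chain carbon would stand relative to the two pairs.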